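The source may report more compounds than this note shows. Statements on the series, on what has been measured and on what is new or still open speak of the compounds shown alone.

Measured so far:
compound 1 `CC1=C(C(=O)Nc2ccc(F)cc2)C(c2ccccc2)NC(=O)N1` — > 100000 nM
compound 2 `CC1=C(C(=O)Nc2ccccc2Cl)C(c2ccc(Cl)cc2)NC(=O)N1` — "non-toxic" (no number reported)

Of the compounds shown here, two have been tested in an ADME assay on Vero cells (Chlorocebus sabaeus) for cytotoxicity, read by XTT assay, with a stated time of 72 h; a higher number here means that more compound is tolerated, a lower number that less compound is tolerated. For compound 1 the result is a limit of the assay rather than a number, > 100000 nM, meaning the cells tolerated the highest concentration tried. Compound 2 is simply recorded as "non-toxic" (no number reported), without a number. On the numbers shown, compound 1 therefore stands at the limit (the limit of > 100000 nM in this assay, at which 1 of the 2 values shown sits), and nothing places it anywhere more precisely.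

Compound 3 `CC1=C(C(=O)Oc2ccccc2)C(c2ccccc2)NC(=O)N1` has not yet been measured in this assay. It differs from compound 1 in one place: phenoxy in place of (4-fluorophenyl)amino on a carbonyl carbon. Among the compounds with values here, because both measured entries sit at the limit of > 100000 nM in this assay, at which 1 of the 2 values shown sits, or carry no number, there is no measured step to lean on; the expected step from compound 1 to compound 3 is a number no higher from compound 1 to compound 3 (the limit leaves the size open), which is none beyond the scatter. Compound 3 is accordingly estimated at 100000 nM, within 30000 nM to 300000 nM, most likely again reported only as a limit.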

Compound 3, half-maximal cytotoxic concentration: > 100000 nM
Compound 3: a limit, no number; the forecaster's own chance of this, stated with the estimate: 80%; the middle value sits exactly at the limit.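

Within the data shown here, compound 1 and compound 3 both end at a limit of this assay rather than at a number, so no step between them can be read: the limit of > 100000 nM in this assay, at which 2 of the 3 values shown sit. The compounds shown leave open at what concentration, if any, the cells stop tolerating either compound, and whether phenoxy in place of (4-fluorophenyl)amino changes that concentration.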